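The source may hold more compounds than are shown below. What is called first, only, known or untested is meant among the compounds shown, and "the series" means these compounds.

Of the compounds shown here, three that share one core have been measured in an assay on isolated protein with Bile acid receptor (Homo sapiens) as the target; on this read-out lower numbers stand for an effect already at smaller amounts and higher numbers for an effect only at larger amounts of compound. Compound 1 `COC(=O)/C=C/c1cccc(N(Cc2ccc(/C=C/c3ccccc3F)cc2)C(=O)C2CCCCC2)c1` gives 64 nM, compound 2 `COC(=O)/C=C/c1cccc(N(Cc2ccc(-c3ccc(OC)cc3)cc2)C(=O)C2CCCCC2)c1` gives 89 nM, and compound 3 `COC(=O)/C=C/c1cccc(N(Cc2ccc(-c3c(OC)cccc3OC)cc2)C(=O)C2CCCCC2)c1` gives 77 nM. Compound 3 differs from the other two only in the group on one aromatic carbon, and the steps of a 1.2-fold higher number from compound 1 to compound 3 (0.08 log units; within the scatter) and a 1.2-fold lower number from compound 2 to compound 3 (0.06 log units; within the scatter) show that exchanging one such group for another leaves the numbers within the scatter, as does a 1.4-fold higher number from compound 1 to compound 2 (0.14 log units; within the scatter). Compound 4 `COC(=O)/C=C/c1ccc(CN(C(=O)C2CCCCC2)c2cccc(/C=C/C(=O)OC)c2)cc1` carries a different kind of change at that carbon: 2-(methoxycarbonyl)ethenyl in place of 2,6-dimethoxyphenyl on an aromatic carbon. Going by the values given here, none of the measured steps removes the ring in this way, so they give only indirect guidance and leave room for a shift. For compound 4 the expected number is 200 nM, with a range of 60 nM to 700 nM, which means an estimated step of a 2.6-fold higher number from compound 3 to compound 4 (0.41 log units; beyond the scatter).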

Compound 4, half-maximal effective concentration: > 1000 nM
Compound 4: no number, only a limit; the forecaster's own chance of this, stated with the estimate: 5%; middle value at least 5.0-fold (0.69 log units) from the limit.
By their numbers in this assay, from the lowest: compounds 1, 3 and 2 (each within the scatter of the next). At a limit, above all of these: compound 4.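

In this assay compound 4 gives only a limit, not a number: the limit of > 1000 nM in this assay, at which 1 of the 4 values shown sits. Unlike the exchanges among ring-bearing groups at this aromatic carbon, 2-(methoxycarbonyl)ethenyl in place of an aryl group gives large steps, namely an at least 12-fold higher number from compound 3 to compound 4 (1.11 log units; beyond the scatter) and an at least 11-fold higher number from compound 2 to compound 4 (1.05 log units; beyond the scatter). The step that keeps the double-bonded chain and puts methoxycarbonyl in place of 2-fluorophenyl is also large, an at least 15-fold higher number from compound 1 to compound 4 (1.19 log units; beyond the scatter), so the chain alone does not preserve the effect.

Going by these compounds, it remains open whether the shift follows the lost aromatic ring or the methoxycarbonyl group itself. A cyclohexyl group or a carboxylic acid at the end of the chain could help separate the two.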